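The source may hold more compounds than are shown below. What is called first, only, known or untested is meant among the compounds shown, and "the series" means these compounds.

Measured so far:
Compound 1 `Oc1ccc(-c2cc(-c3ccc(Cl)cc3)nc(-c3cccnc3)c2)cc1` — 20700 nM
Compound 2 `Oc1ccc(-c2cc(-c3cccs3)nc(-c3ccccc3Cl)c2)cc1` — 5430 nM
Compound 3 `Oc1ccc(-c2cc(-c3ccc(Cl)cc3)nc(-c3cccs3)c2)cc1` — 6470 nM

These three compounds were tested in a functional assay on HCT-15 cells (Homo sapiens) for cytotoxicity, read by CCK-8 assay and cell counting, with a stated time of 2 days; a higher number here means a weaker inhibitor, a lower number a stronger inhibitor. Compound 3 stands second highest of the three numbers; its nearest neighbour is compound 2, and the gap a 1.2-fold higher number from compound 2 to compound 3 (0.08 log units; within the scatter) is within the scatter. Its furthest neighbour is compound 1, and the step of a 3.2-fold lower number from compound 1 to compound 3 (0.51 log units; beyond the scatter) is beyond the scatter.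

Compound 4 `Oc1ccc(-c2cc(-c3ccc(Cl)cc3)nc(-c3ccsc3)c2)cc1` differs from compound 3 by one change: thiophen-3-yl in place of thiophen-2-yl on an aromatic carbon. Within the data shown here, no measured step swaps one thiophenyl attachment for the other, so nothing bears directly on this change. The expectation is therefore that compound 4 shows no step beyond the scatter, a 1.0-fold higher number from compound 3 to compound 4 (0.00 log units; within the scatter). In this assay compound 4 is estimated at 6500 nM, between 3000 nM and 14000 nM.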

Compound 4, half-maximal inhibitory concentration: 6240 nM
Beside the measured number, compound 4's estimate is 1.0-fold (0.02 log units) above it, and the stated range covers the measured number.
By their numbers in this assay, from the lowest: compounds 2, 4 and 3 (each within the scatter of the next); then compound 1.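

Moving the attachment point of the thiophene at this place next to the ring nitrogen gives a 1.0-fold lower number from compound 3 to compound 4 (0.02 log units; within the scatter) in this assay and so leaves the number unchanged within the scatter. Thiophen-3-yl also stands apart from pyridin-3-yl, with a 3.3-fold lower number from compound 1 to compound 4 (0.52 log units; beyond the scatter), so both thiophene attachments now give that same separation from the pyridine. No available evidence explains either step. From the compounds shown here alone, whether a furan-2-yl group or a simple amine here would give numbers like the thiophenes remains open.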